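This account rests on a few compounds, and the source may have more. Where it says the series, first, only, none or still open, it means among the compounds named here.

Compound 1 `O=C1COc2ccc(-c3[nH]c(-c4ccc(F)cc4)nc3-c3ccccc3)cc2N1` is one of three compounds that share a core and were examined in a functional assay on A549 cells (Homo sapiens) for cytotoxicity, read by colorimetric assay and MTT assay, with a stated time of 3 days, tested at 1 uM; a lower number here means a stronger effect, a higher number a weaker effect of the compound at the concentration tested. In this assay compound 1 gives 97.1%, the highest of the three numbers; compound 2 `O=C1COc2ccc(-c3nn(-c4ccc(Br)cc4)cc3-c3ccccc3)cc2N1` gives 81.5% and compound 3 `O=C1COc2ccc(-c3nn(-c4ccc(F)cc4)cc3-c3ccccc3)cc2N1` gives 78.2%. For the measured compounds named here, the only halogen exchange measured, a number 3.3 percentage points lower from compound 2 to compound 3 (within the scatter), lies within the scatter. Compound 4 `O=C1COc2ccc(-c3[nH]c(-c4ccc(Cl)cc4Cl)nc3-c3ccccc3)cc2N1` differs from compound 1 by 2,4-dichlorophenyl in place of 4-fluorophenyl on an aromatic carbon. Going by the values given here, since the one halogen change seen in the set stayed within the scatter, no step beyond the scatter is expected from compound 1 to compound 4 in this assay. Compound 4 is therefore estimated at 93%, in a range from 78% to 106%, an expected step of a number 4.1 percentage points lower from compound 1 to compound 4 (within the scatter).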

Compound 4, a percentage reported as activity, at one concentration (the size of the read-out at that concentration, not a potency): 97.4%
Compound 4: the middle estimate sits 4.4 percentage points below what was measured; low and high end bracket the measured number.
By their numbers in this assay, from the lowest: compounds 3 and 2 (each within the scatter of the next); then compounds 1 and 4 (each within the scatter of the next).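

Placing 2,4-dichlorophenyl in place of 4-fluorophenyl on the aromatic carbon between two ring nitrogen atoms gave a number 0.3 percentage points higher from compound 1 to compound 4 (within the scatter) in this assay. The earlier halogen exchange, seen only between compound 2 and compound 3, involved one halogen for another, whereas this change, on the core of compound 1, brings two chlorine atoms and still leaves the read-out within the scatter. Nothing available explains this result. On these data alone, what an amine or a carboxylic acid at this position would do stays open, as does whether any group here can lower the number beyond the scatter.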